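Hydrazone aryl swap on the oxadiazole benzamide series

This account rests on a few compounds, and the source may have more. Where it says the series, first, only, none or still open, it means among the compounds named here.

Compound 2 `COc1ccccc1-c1nnc(-c2ccc(C(=O)N/N=C/c3cccnc3)cc2)o1` and compound 1 `COc1ccccc1-c1nnc(-c2ccc(C(=O)N/N=C/c3ccc([N+](=O)[O-])cc3)cc2)o1` share the core and differ only at the carbon with a double bond to nitrogen. In an ADME assay on THP-1 cells (Homo sapiens) for cytotoxicity (on this read-out higher numbers stand for weaker inhibition and lower numbers for stronger inhibition), compound 1 gives 203000 nM and compound 2 gives 167000 nM; the step of a 1.2-fold lower number from compound 1 to compound 2 (0.08 log units; within the scatter) leaves the two within the scatter of each other, so neither stands apart. Compound 3 `COc1ccccc1-c1nnc(-c2ccc(C(=O)N/N=C/c3ccc(O)cc3O)cc2)o1` carries 2,4-dihydroxyphenyl in place of pyridin-3-yl on a carbon with a double bond to nitrogen. Among the measured compounds shown here, the only comparable step, the aryl exchange at this position, gave no separation, so compound 3 is expected to show no step beyond the scatter; the estimated step of a 1.0-fold higher number from compound 2 to compound 3 (0.01 log units; within the scatter) is essentially flat. Compound 3 is therefore estimated at 170000 nM, with a range from 80000 nM to 360000 nM.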

Compound 3, half-maximal inhibitory concentration: 104000 nM
The estimate for compound 3 lay 1.6-fold (0.21 log units) above the measured number; the measured number falls inside the stated range.
By their numbers in this assay, from the lowest: compounds 3, 2 and 1 (each within the scatter of the next).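

At the carbon with a double bond to nitrogen, a third aryl group still gives no separation in this assay: both a 1.6-fold lower number from compound 2 to compound 3 (0.21 log units; within the scatter) and a 2.0-fold lower number from compound 1 to compound 3 (0.29 log units; within the scatter) leave all three compounds together. The pyridin-3-yl compounds and the nitro compound are thus joined by 2,4-dihydroxyphenyl, which adds hydrogen-bond donors without a step beyond the scatter. No supporting data bear on this result. From the compounds shown here alone, whether an aliphatic amine or a carboxylic acid on this ring, or an alkyl chain replacing the ring, would move the number beyond the scatter stays open.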